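Cytotoxicity notes: methoxy on the phenyl ring

The source may hold more compounds than are shown below. What is called first, only, known or untested is meant among the compounds shown, and "the series" means these compounds.

Measured so far:
compound 1 `Nc1nc(-c2ccccc2)cn1/N=C/c1cc2ccccc2nc1Cl`: 46700 nM
compound 2 `Cc1ccc2nc(Cl)c(/C=N/n3cc(-c4ccccc4)nc3N)cc2c1`: 41500 nM

In an ADME assay on HUVEC cells (Homo sapiens) for cytotoxicity, read by MTT assay, with a stated time of 48 h (a higher number here means a weaker inhibitor, a lower number a stronger inhibitor), compound 1 gives 46700 nM and compound 2 gives 41500 nM. Compound 2 sits at the bottom of the two numbers, but the step of a 1.1-fold lower number from compound 1 to compound 2 (0.05 log units; within the scatter) is within the scatter, so the two compounds cannot be told apart in this assay on present data.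

Compound 3 `COc1ccc(-c2cn(/N=C/c3cc4cc(C)ccc4nc3Cl)c(N)n2)cc1` is the next member. It differs from compound 2 by methoxy in place of hydrogen on an aromatic carbon. Going by the values given here, no measured step touches this position: the only step known, a 1.1-fold lower number from compound 1 to compound 2 (0.05 log units; within the scatter), concerns a methyl on the shared core, not the phenyl ring, and it was within the scatter. The series therefore offers no evidence that a small substituent on the periphery moves the cytotoxicity number, and nothing points in either direction for a methoxy.

The expectation is accordingly a step of a 1.0-fold lower number from compound 2 to compound 3 (0.02 log units; within the scatter), that is, none beyond the scatter. For compound 3 the estimated value in this assay is 40000 nM, with a range of 15000 nM to 100000 nM.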

Compound 3, half-maximal inhibitory concentration: 12200 nM
Estimate against measurement, compound 3: 3.3-fold (0.52 log units) above; measured number below the stated range.
By their numbers in this assay, from the lowest: compound 3; then compounds 2 and 1 (each within the scatter of the next).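

Going by these compounds alone, the phenyl ring is a position that responds in this assay: phenyl to 4-methoxyphenyl gives a 3.4-fold lower number from compound 2 to compound 3 (0.53 log units; beyond the scatter), the only step beyond the scatter. The methyl on the shared core, with a 1.1-fold lower number from compound 1 to compound 2 (0.05 log units; within the scatter), stayed within the scatter, so a small peripheral change cannot be assumed silent here; on present data, the methoxy para to a large group moves the number while the core methyl does not visibly do so. The step is modest, rests on a single pair of compounds, and no measurement at hand bears on what lies behind it.

Going by these compounds, it remains open whether this step belongs to the methoxy itself or would follow from other groups on the same carbon, such as a hydroxyl, a fluorine, an amine or a longer chain like ethoxy. On these data alone, it also remains open whether phenyl to 4-methoxyphenyl gives a step of similar size on the core of compound 1, which would show whether the change holds without the methyl.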